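Chain amine swap on two cores: a parallel step

A few compounds are considered here, and "the series" means these few. Any claim that something is new, unique, unknown or untested is made for them only; others in the source may bear on it.

Compound 1 `CCN(CC)CCn1c(N)c(-c2nc3ccccc3n2C)c2nc(C#N)c(C#N)nc21` and compound 2 `CN(C)CCCn1c(N)c(-c2nc3ccccc3n2C)c2nc(C#N)c(C#N)nc21` share one core and differ only in the basic chain. In a functional assay on A549 cells (Homo sapiens) for antiproliferative activity, read by MTT assay, with a stated time of 48 h (a lower number here means a stronger inhibitor, a higher number a weaker inhibitor), compound 1 reaches only the limit, > 50000 nM, and that value is a limit rather than a number. Compound 2 gives 11700 nM in this assay. The step of an at least 4.2-fold lower number from compound 1 to compound 2 (0.63 log units; beyond the scatter) is the change ((dimethylamino)methyl in place of diethylamino on a saturated chain carbon, two bonds along the chain from an aromatic nitrogen); its size can only be bounded from below because of the limit of > 50000 nM in this assay, at which 2 of the 3 values shown sit.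

Compound 3 `CCN(CC)CCCn1c(N)c(-c2nc3cc(Cl)ccc3[nH]2)c2nc(C#N)c(C#N)nc21` sits on a second core; how the two cores differ is not broken down here. In this assay compound 3 returns the limit > 50000 nM, a limit and not a number. Compound 4 `CN(C)CCCCn1c(N)c(-c2nc3cc(Cl)ccc3[nH]2)c2nc(C#N)c(C#N)nc21`, not yet measured, differs from compound 3 by (dimethylamino)methyl in place of diethylamino on a saturated chain carbon, three bonds along the chain from an aromatic nitrogen. The place differs from the first pair: three bonds along the chain from an aromatic nitrogen against two bonds there, so this is the same kind of change, not the same change.

The step of an at least 3.3-fold lower number from compound 3 to compound 4 (0.52 log units; beyond the scatter) is expected, resting on compound 1 to compound 2 an at least 4.2-fold lower number from compound 1 to compound 2 (0.63 log units; beyond the scatter). Compound 4 is therefore estimated at 15000 nM, expected between 4000 nM and 50000 nM.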

Compound 4, half-maximal inhibitory concentration: 12100 nM
Compound 4: middle estimate off by 1.2-fold (0.09 log units), on the high side, and the stated range covers the measured number.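

In this assay, putting (dimethylamino)methyl in place of diethylamino on the core of compound 3 gives an at least 4.1-fold lower number from compound 3 to compound 4 (0.61 log units; beyond the scatter), so the change points the same way on both cores shown, although at a different place on the chain. Set side by side, the two steps give no sign of a difference in size, and none can be claimed: the same change on two cores in this assay, an at least 4.2-fold lower number (0.63 log units; beyond the scatter) from compound 1 to compound 2 and an at least 4.1-fold lower number (0.61 log units; beyond the scatter) from compound 3 to compound 4; the limit leaves it open whether they differ. Compound 3 stands at > 50000 nM, a limit and not a number, so the pair fixes a direction and a lower bound, not a size that carries from one core to the other: the limit of > 50000 nM in this assay, at which 2 of the 4 values shown sit.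

As far as these compounds go, each step replaces the amine and lengthens the chain together, as in 3-(diethylamino)propyl to 4-(dimethylamino)butyl, so the share of each remains open; a 3-(dimethylamino)propyl chain on the core of compound 3 would separate the two. Also open, from the compounds shown here alone, is whether a morpholine at the chain end, or a chain longer than 4-(dimethylamino)butyl, follows the same direction in this assay.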